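Compound 2 Gives Up Its (4-Cyclopropylpiperazin-1-yl)methyl Group

The compounds below may be only part of what the source reports. "The series", "measured", "known", "first", "only" and "open" are said of these compounds alone.

Among the measured compounds shown here, in an ADME assay for permeability, using PAMPA, with a stated time of 4 h, at pH 7.4 (a higher number here means that the compound crosses the layer faster, a lower number that the compound crosses the layer more slowly), compound 1 (`c1ccc2c(c1)CN[C@@H](CN(CCC1CCNCC1)[C@H]1CCCc3cccnc31)C2`) gives 19 nm/s and compound 2 (`c1ccc2c(c1)CN[C@@H](CN(CCCN1CCN(C3CC3)CC1)[C@H]1CCCc3cccnc31)C2`) gives 505 nm/s, so compound 2 holds the higher of the two numbers measured so far. Compound 3 (`c1ccc2c(c1)CN[C@@H](CN(CC[C@H]1CCCNC1)[C@H]1CCCc3cccnc31)C2`) has not yet been measured. It carries piperidin-3-yl in place of (4-cyclopropylpiperazin-1-yl)methyl on a saturated chain carbon, two bonds along the chain from an amine nitrogen. For the measured compounds named here, only one measured step bears on this change: a 27-fold higher number from compound 1 to compound 2 (1.42 log units; beyond the scatter), a large step beyond the scatter, in which (4-cyclopropylpiperazin-1-yl)methyl replaced piperidin-4-yl. Compound 3 partly reverses that exchange, though with piperidin-3-yl rather than piperidin-4-yl, and no measurement compares those two groups. A large fall of similar size is therefore expected in this assay, and the expected step is a 20-fold lower number from compound 2 to compound 3 (1.31 log units; beyond the scatter). For compound 3 the estimated value is 25 nm/s, with an expected range of 8 nm/s to 80 nm/s.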

Compound 3, apparent permeability: 55 nm/s
Beside the measured number, compound 3's estimate is 2.2-fold (0.34 log units) below it, within the range that was stated.
By their numbers in this assay, from the lowest: compound 1; then compound 3; then compound 2.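

Compound 3 shows that the number at this position, on a saturated chain carbon, two bonds along the chain from an amine nitrogen, does not depend only on whether (4-cyclopropylpiperazin-1-yl)methyl is present. In this assay, among the compounds shown here, the exchange for piperidin-3-yl gives a 9.2-fold lower number from compound 2 to compound 3 (0.96 log units; beyond the scatter), while the first comparison of the two piperidine attachments gives a 2.9-fold higher number from compound 1 to compound 3 (0.46 log units; beyond the scatter), so the choice between piperidin-3-yl and piperidin-4-yl also changes the result beyond the scatter. No measurement offered here explains either step.

The compounds shown leave open whether the high number of compound 2 goes with its piperazine ring or with its cyclopropyl ring, a question that a piperazin-1-ylmethyl group without the cyclopropyl would address. As far as these compounds go, the mirror-image form of piperidin-3-yl also remains open, as compound 3 carries a single defined stereocentre.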